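Removing the side chain from compound 1

The source may hold more compounds than are shown below. What is called first, only, known or untested is meant among the compounds shown, and "the series" means these compounds.

Measured in an ADME assay on WI-38 cells (Homo sapiens) for cytotoxicity, read by MTT assay, with a stated time of 48 h; a lower number here means a stronger inhibitor, a higher number a weaker inhibitor:
Compound 1 `Cc1n[nH]c2c1C(c1ccc(N(C)C)cc1)C(C(=O)NNC(N)=S)=C(N)N2` gives 53500 nM
Compound 2 `Cc1n[nH]c2c1C(c1ccc(N(C)C)cc1)C(C(=O)NNc1cc([N+](=O)[O-])ccc1[N+](=O)[O-])=C(N)N2` gives 55400 nM

Among the measured compounds shown here, only two numbers exist so far, and the one measured step is a 1.0-fold higher number from compound 1 to compound 2 (0.02 log units; within the scatter) and came from a swap on an amine nitrogen. For the measured compounds named here, compound 1 therefore holds no rank of its own and sits level with its only neighbour. Compound 3 `Cc1n[nH]c2c1C(c1ccc(N(C)C)cc1)C=C(N)N2` goes much further, with a hydrogen atom in place of a group of 7 heavy atoms (2 carbon, 3 nitrogen, 1 oxygen, 1 sulfur; no ring), on a double-bonded ring carbon as its change. The swapped amine nitrogen lies within the group that leaves, so the measured step bears on this change only in part. Going by the values given here, no measured compound shows the shared core without that group. Among the compounds with values here, the only guide is still a 1.0-fold higher number from compound 1 to compound 2 (0.02 log units; within the scatter) and it points to no shift, so in this assay no step beyond the scatter is expected, though with real uncertainty. The expected step is a 1.0-fold higher number from compound 1 to compound 3 (0.01 log units; within the scatter) and it stays within the scatter. Compound 3 is estimated at 55000 nM with an expected range from 22000 nM to 130000 nM as the likely span.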

Compound 3, half-maximal inhibitory concentration: 18100 nM
For compound 3 the middle estimate is 3.0-fold (0.48 log units) above the measured one; the measured number lies below the stated range.
By their numbers in this assay, from the lowest: compound 3; then compounds 1 and 2 (each within the scatter of the next).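

In this assay, the side chain on the double-bonded ring carbon turns out to matter: replacing it with a hydrogen atom gives a 3.0-fold lower number from compound 1 to compound 3 (0.47 log units; beyond the scatter), a modest step but one beyond the scatter. Among the compounds shown here, the earlier pair showed only that a swap on an amine nitrogen inside this chain left the number level, whereas this step concerns the whole group, with its 3 hydrogen-bond donors and 2 hydrogen-bond acceptors, and shows that the lower number goes with a bare hydrogen at this position. Nothing available explains this shift, so it stands as an observation without a known cause.

The compounds shown leave open whether the whole group or only part of it goes with the higher number, and a small group on the same ring carbon, such as a carboxylic acid, a nitrile or a simple primary amide, would help to separate those possibilities. Going by these compounds, it also remains open whether the step would hold with another group in place of the 4-(dimethylamino)phenyl group, which all three compounds carry.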